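A few compounds are considered here, and "the series" means these few. Any claim that something is new, unique, unknown or untested is made for them only; others in the source may bear on it.

Measured compounds:
- compound 3 `CC(C)(C)C1=NN(c2cccc(Cl)c2)C(c2ccc(O)cc2)C1` — 5200 nM
- compound 1 `CC(C)c1ccc(N2N=C(C(C)(C)C)CC2c2ccc(O)cc2)cc1` — "not determined" (no result reported)
- compound 2 `CC(C)(C)C1=NN(c2ccc(C(=O)O)cc2)C(c2ccc(O)cc2)C1` — "not determined" (no result reported)

Three compounds share a core and differ in the group carried on the pendant aromatic ring. For the measured compounds named here, in an assay on isolated protein for inhibition of protein kinase C zeta type (Homo sapiens), with a stated time of 4 min (on this read-out higher numbers stand for weaker inhibition and lower numbers for stronger inhibition), compound 3 gives 5200 nM, the only number in this set. Going by the values given here, for compound 1 this assay reports "not determined" (no result reported), and for compound 2 this assay reports "not determined" (no result reported), so compound 3 stands alone and no comparison between measured compounds can be drawn.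

Compound 4 `Cc1cccc(N2N=C(C(C)(C)C)CC2c2ccc(O)cc2)c1` has not yet been measured. It differs from compound 3 by methyl in place of chloro on an aromatic carbon, meta to a large group. Among the compounds with values here, with no measured pair showing the size of such a change, the step from chloro to methyl is expected to stay within the usual scatter, with no clear direction; the expected step is a 1.2-fold higher number from compound 3 to compound 4 (0.06 log units; within the scatter). Compound 4 is therefore estimated at 6000 nM, with a range from 2500 nM to 15000 nM.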

Compound 4, half-maximal inhibitory concentration: 3500 nM
For compound 4 the middle estimate is 1.7-fold (0.23 log units) above the measured one; the range from low to high includes it.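

For the compounds shown here, the exchange of 3-chlorophenyl for 3-methylphenyl provides the first measured pair in this set, and this assay records a 1.5-fold lower number from compound 3 to compound 4 (0.17 log units; within the scatter) for it. At this place on the pendant ring, then, methyl in place of chloro leaves the number within the usual scatter, so this single pair gives the change no direction. No measured information is available to explain this result.

The compounds shown leave open whether the number would move with a different group at this place, such as an amine, a methoxy group or a longer chain. They also leave open whether methyl in place of chloro would read the same on another carbon of the ring, and compound 1 and compound 2 offer no help, as neither has a number.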